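The source may report more compounds than this note shows. Statements on the series, on what has been measured and on what is new or still open speak of the compounds shown alone.

Values in an ADME assay on BE(2)-C cells (Homo sapiens) for cytotoxicity, read by MTT assay, with a stated time of 20 h; on this read-out lower numbers stand for higher toxicity in this test and higher numbers for lower toxicity in this test:
- compound 1 `O=C(c1cc2ccccc2n1Cc1ccc(Cl)cc1)N1CCC(C(=O)N2CCC[C@H]2CO)CC1` gives 98900 nM
- compound 2 `CN(Cc1ccccc1)C(=O)C1CCN(C(=O)c2cc3ccccc3n2Cc2ccc(Cl)cc2)CC1` gives 87000 nM
- compound 3 `COc1ccc(Cn2c(C(=O)N3CCC(C(=O)N(C)Cc4ccccc4)CC3)cc3ccccc32)cc1` gives 99200 nM

Compound 3 (99200 nM) stands level with compound 1 and compound 2, as all three values lie within the scatter of one another. The unmeasured compound 4 (`CN(Cc1ccccc1)C(=O)C1CCN(C(=O)c2cc3ccccc3n2Cc2ccncc2)CC1`) differs from compound 3 as follows: pyridin-4-yl in place of 4-methoxyphenyl on a saturated chain carbon bound to an aromatic nitrogen (pyridin-4-yl in place of 4-methoxyphenyl on a saturated chain carbon bound to an aromatic nitrogen; cut one bond further out, 4-methoxybenzyl to (pyridin-4-yl)methyl).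

For the measured compounds named here, two measured steps bear on this. The closer one, a 1.1-fold higher number from compound 2 to compound 3 (0.06 log units; within the scatter), has methoxy in place of chloro on an aromatic carbon, within the group that leaves here. The other, a 1.1-fold lower number from compound 1 to compound 2 (0.06 log units; within the scatter), has benzyl(methyl)amino in place of 2-(hydroxymethyl)pyrrolidin-1-yl on a carbonyl carbon, elsewhere in the structure. Both stay within the scatter. Going by the values given here, neither replaces the aromatic ring itself, so the series offers no direct precedent for this change, and the range is kept wide.

In this assay the estimated step is a 1.1-fold lower number from compound 3 to compound 4 (0.04 log units; within the scatter), and no step beyond the scatter is expected in either direction. Compound 4 is expected at 90000 nM, with an estimated range from 45000 nM to 150000 nM.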

Compound 4, half-maximal cytotoxic concentration: 80300 nM
Beside the measured number, compound 4's estimate is 1.1-fold (0.05 log units) above it; low and high end bracket the measured number.
By their numbers in this assay, from the lowest: compounds 4, 2, 1 and 3 (each within the scatter of the next).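

In this assay, the aromatic ring itself on the saturated chain carbon bound to an aromatic nitrogen is now exchanged, not just a substituent on it: pyridin-4-yl in place of 4-methoxyphenyl gives (a 1.2-fold lower number from compound 3 to compound 4 (0.09 log units; within the scatter)) and pyridin-4-yl in place of 4-chlorophenyl gives (a 1.1-fold lower number from compound 2 to compound 4 (0.03 log units; within the scatter)). Across compound 2, compound 3 and compound 4, this position therefore takes a six-membered aromatic ring with 1 hetero atom as well as a ring of carbon only, with no step beyond the scatter, which extends the earlier finding from an exchange of ring substituents to an exchange of the ring itself. No supporting measurement bears on this result.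

Still open, as far as these compounds go, is whether any group at this position moves the number beyond the scatter, for example a carboxylic acid or a saturated amine such as piperidin-4-yl in place of the aromatic ring, or a longer chain in place of the (pyridin-4-yl)methyl group. Also open, from the compounds shown here alone, is whether pyridin-2-yl or pyridin-3-yl reads the same as pyridin-4-yl, and whether the flat picture holds for the other amide group of the series when the ring here is pyridin-4-yl.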